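Chalcone series: aromatic dimethylamino and monoamine oxidase A inhibition

The source may report more compounds than this note shows. Statements on the series, on what has been measured and on what is new or still open speak of the compounds shown alone.

Measured compounds:
compound 1 `CCN(CC)CCCOc1ccc(C(=O)/C=C/c2ccc(N(C)C)cc2)c(O)c1` — 47100 nM
compound 2 `CCN(CCCOc1ccc(C(=O)/C=C/c2ccc(N(C)C)cc2)c(O)c1)Cc1ccccc1` — 82600 nM
compound 3 `CCN(CCCOc1ccc(C(=O)/C=C/c2ccccc2)c(O)c1)Cc1ccccc1N(C)C` — 67800 nM

All three measured compounds give weak inhibition in an assay on isolated protein for inhibition of Amine oxidase [flavin-containing] A (Homo sapiens); on this read-out lower numbers stand for stronger inhibition and higher numbers for weaker inhibition. Compound 3 stands second highest of the three numbers; compound 2 and compound 1 both lie within the scatter of it. Among the compounds with values here, the only measured single-point step, a 1.8-fold higher number from compound 1 to compound 2 (0.24 log units; within the scatter), concerns a different part of the molecule and is itself within the scatter. Compound 4 `CCN(CCCOc1ccc(C(=O)/C=C/c2ccc(N(C)C)cc2)c(O)c1)Cc1ccccc1N(C)C` arises from compound 3 by dimethylamino in place of hydrogen on an aromatic carbon. Within the data shown here, no measured step bears directly on this change; compound 1 and compound 2, which both carry a dimethylamino group on the same aromatic ring, give values within the scatter of compound 3. Accordingly, no step beyond the scatter is expected, a 1.0-fold higher number from compound 3 to compound 4 (0.01 log units; within the scatter). Compound 4 is estimated at 70000 nM, expected between 35000 nM and 140000 nM.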

Compound 4, half-maximal inhibitory concentration: 23600 nM
Beside the measured number, compound 4's estimate is 3.0-fold (0.47 log units) above it; measured number outside the range, below it.
By their numbers in this assay, from the lowest: compounds 4, 1, 3 and 2 (each within the scatter of the next, the first and the last beyond it).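

In this assay, within the data shown here, dimethylamino in place of hydrogen on an aromatic carbon, para to a large group, gives the first step beyond the scatter (a 2.9-fold lower number from compound 3 to compound 4 (0.46 log units; beyond the scatter)). The same replacement on a second aromatic carbon also goes beyond it (a 3.5-fold lower number from compound 2 to compound 4 (0.54 log units; beyond the scatter)), whereas 2-(dimethylamino)phenyl in place of methyl on the chain carbon stays within it (a 2.0-fold lower number from compound 1 to compound 4 (0.30 log units; within the scatter)). No evidence is available that bears on these steps.

Open, from the compounds shown here alone, is whether methoxy or a primary amine on the same aromatic carbon gives a comparable step.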